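Moving a Methoxy Group to Another Place on the Ring

A few compounds are considered here, and "the series" means these few. Any claim that something is new, unique, unknown or untested is made for them only; others in the source may bear on it.

Among the measured compounds shown here, compound 3 `COc1ccc(N2CCN(Cn3nc(-c4ccc5c(c4)OCCO5)oc3=S)CC2)cc1` is one of three compounds measured in a functional assay on HepG2 cells (Homo sapiens) for antiproliferative activity, read by MTT assay, with a stated time of 48 h; on this read-out higher numbers stand for weaker inhibition and lower numbers for stronger inhibition. In this assay compound 3 gives only a limit, > 50000 nM, so no number is known for it. Compound 1 `S=c1oc(-c2ccc3c(c2)OCCO3)nn1CN1CCN(c2ccc(Cl)cc2)CC1` likewise gives only a limit, > 50000 nM. For the measured compounds named here, compound 2 `S=c1oc(-c2ccc3c(c2)OCCO3)nn1CN1CCN(C(c2ccccc2)c2ccccc2)CC1`, which carries a diphenylmethyl group in place of the aryl group, is the one compound with a number, 9120 nM. Going by the values given here, the single step between measured compounds that differ in one place, a step that the two limits leave unreadable from compound 1 to compound 3, cannot be read because both of its ends sit at the limit of > 50000 nM in this assay, at which 2 of the 3 values shown sit.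

Compound 4 `COc1ccccc1N1CCN(Cn2nc(-c3ccc4c(c3)OCCO4)oc2=S)CC1` differs from compound 3 in one place: 2-methoxyphenyl in place of 4-methoxyphenyl on an amine nitrogen in a ring. The two hold the same atoms, joined differently. Among the compounds with values here, no measured step bears directly on this change, and the only step that is known at all is unreadable, so there is nothing to suggest a shift beyond the scatter in this assay in either direction. Compound 3 stands at the limit, and compound 4 is therefore expected to stand near it as well. The estimate for compound 4 is 50000 nM, with a range from 15000 nM to 150000 nM. The step of a number no higher from compound 3 to compound 4 (the limit leaves the size open) is expected to be small.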

Compound 4, half-maximal inhibitory concentration: 15500 nM
The estimate for compound 4 lay 3.2-fold (0.51 log units) above the measured number, and the stated range covers the measured number.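

In this assay, the arrangement of the aryl group on the piperazine-type amine nitrogen matters even when no atom is added or lost: going from 4-methoxyphenyl to 2-methoxyphenyl gives an at least 3.2-fold lower number from compound 3 to compound 4 (0.50 log units; beyond the scatter). Among the compounds shown here, the change from 4-chlorophenyl to 2-methoxyphenyl at the same place gives an at least 3.2-fold lower number from compound 1 to compound 4 (0.50 log units; beyond the scatter), so compound 4 is the first compound with an aryl group directly on this nitrogen to give a number rather than a limit. Both steps can be stated only as lower bounds, and their true size stays open, because compound 1 and compound 3 each give only a limit: the limit of > 50000 nM in this assay, at which 2 of the 4 values shown sit.

The compounds shown do not tell whether the change in this assay depends on the methoxy group itself or would also appear with an ethoxy group, a hydroxy group or a chlorine in its place on the 2-substituted ring. They also leave open how a plain phenyl group would compare with 2-methoxyphenyl at this place, which would show whether the methoxy group adds anything to the aryl ring alone.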